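The compounds below may be only part of what the source reports. "The series", "measured", "known", "first", "only" and "open" are said of these compounds alone.

Three compounds share one core and differ only at a single aromatic carbon. Compound 1 `Cc1nc(-c2ccsc2)cc2nn(-c3ccccc3)cc12` carries a thiophen-3-yl group there, and in a functional assay on MCF7 cells (Homo sapiens) for inhibition, read by fluorescence, with a stated time of 72 h (a higher number here means a weaker inhibitor of growth, a lower number a stronger inhibitor of growth), compound 1 gives 22200 nM. Compound 2 `CCCCc1cc2nn(-c3ccccc3)cc2c(C)n1` carries a butyl chain instead, and in this assay compound 2 gives 11100 nM. Compound 3 `CCCCCc1cc2nn(-c3ccccc3)cc2c(C)n1` carries a pentyl chain, and in this assay compound 3 gives 17000 nM. Among these three numbers compound 3 stands second highest, though both of its steps stay inside the usual scatter: a 1.5-fold higher number from compound 2 to compound 3 (0.19 log units; within the scatter) and a 1.3-fold lower number from compound 1 to compound 3 (0.12 log units; within the scatter). The remaining pair behaves the same way, with a 2.0-fold lower number from compound 1 to compound 2 (0.30 log units; within the scatter). So far, then, exchanging one group for another at this carbon has not moved the number beyond what repeated measurements would show anyway.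

Compound 4 `Cc1nccc2nn(-c3ccccc3)cc12` has not yet been measured. It removes the chain altogether: hydrogen in place of pentyl on an aromatic carbon. Going by the values given here, no measured step strips this position bare, so the only guides are the three exchanges above, each within the scatter. On that basis the step from compound 3 to compound 4 is expected to be a 1.2-fold higher number from compound 3 to compound 4 (0.07 log units; within the scatter), with no change beyond the scatter in this assay. Compound 4 is therefore estimated at 20000 nM, within a range from 8000 nM to 50000 nM.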

Compound 4, concentration for 50% growth inhibition: > 100000 nM
Compound 4 gave a limit, no number; the forecaster's own chance of this, stated with the estimate: 15%; middle value at least 5.0-fold (0.69 log units) from the limit.
By their numbers in this assay, from the lowest: compounds 2, 3 and 1 (each within the scatter of the next). At a limit, above all of these: compound 4.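

The earlier compounds shown here only traded one group for another at this aromatic carbon, and the number stayed inside the scatter. Leaving bare hydrogen there is the first change that goes beyond it, with an at least 5.8-fold higher number from compound 3 to compound 4 (0.76 log units; beyond the scatter) for the loss of the pentyl chain, an at least 9.0-fold higher number from compound 2 to compound 4 (0.95 log units; beyond the scatter) for the loss of the butyl chain and an at least 4.5-fold higher number from compound 1 to compound 4 (0.65 log units; beyond the scatter) for the loss of thiophen-3-yl. Compound 4 gave a limit and not a number: the limit of > 100000 nM in this assay, at which 1 of the 4 values shown sits. So, among these four compounds, having a group at this position goes with measurable growth inhibition in this assay and having none does not, while a ring and two chains serve about equally well, their numbers lying within the scatter of each other.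

Open, from the compounds shown here alone, is how small the group can become before the number climbs, as nothing between hydrogen and butyl stands here, so a methyl or an ethyl group at this carbon would fill that gap. Also open, going by these compounds, is what a longer chain such as hexyl, a phenyl ring, an amine or a carboxylic acid would do at the same place.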